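Replacing the 4-(tert-butyl)phenyl group of compound 2

A few compounds are considered here, and "the series" means these few. Any claim that something is new, unique, unknown or untested is made for them only; others in the source may bear on it.

Compound 1 `O=C1OCC[C@@H]1NC(=S)SCCOc1ccccc1Cc1ccccc1`: > 64000 nM
Compound 2 `CC(C)(C)c1ccc(/C=C/C(=O)c2ccc(OCC(=O)N[C@H]3CCOC3=O)cc2)cc1`: 6570 nM
Compound 3 `O=C(CNc1ccc(Cl)cc1Cl)N[C@H]1CCOC1=O`: > 64000 nM

All three compounds were tested in a functional assay on DU-145 cells (Homo sapiens) for antiproliferative activity, read by MTT assay, with a stated time of 72 h; on this read-out higher numbers stand for weaker inhibition and lower numbers for stronger inhibition. Among the measured compounds shown here, compound 2 gives 6570 nM, the only actual number among them. Compound 1 stands at > 64000 nM, which is a limit of the assay and not a number. Compound 3 stands at > 64000 nM, which is also a limit.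

Compound 4 `O=C(COc1ccc(C(=O)/C=C/c2cccc(F)c2)cc1)N[C@H]1CCOC1=O` has not yet been measured in this assay. It differs from compound 2 in one place: 3-fluorophenyl in place of 4-(tert-butyl)phenyl on a double-bonded chain carbon bound to a double-bonded chain carbon. In words, 3-fluorophenyl stands in place of 4-(tert-butyl)phenyl on a double-bonded chain carbon bound to a double-bonded chain carbon. For the measured compounds named here, no measured pair shows this change or any other single change. The expectation is therefore tentative: weaker inhibition, by a step somewhat beyond the scatter, since (the limit of > 64000 nM in this assay, at which 2 of the 3 values shown sit). The expected change is a 2.3-fold higher number from compound 2 to compound 4 (0.36 log units; beyond the scatter). For compound 4 the estimate is 15000 nM, with an expected range of 5000 nM to 50000 nM.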

Compound 4, half-maximal inhibitory concentration: 17200 nM
For compound 4 the middle estimate is 1.1-fold (0.06 log units) below the measured one, within the range that was stated.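

In this assay, among the compounds shown here, this is the first pair of compounds that differ in one place, and it shows that the group on the double-bonded chain carbon bound to a double-bonded chain carbon affects the read-out: 3-fluorophenyl in place of 4-(tert-butyl)phenyl gives a 2.6-fold higher number from compound 2 to compound 4 (0.42 log units; beyond the scatter). Even so, compound 4 retains a measured value of 17200 nM, so this change does not remove measurable inhibition. The value is not at the limit reached by other compounds: the limit of > 64000 nM in this assay, at which 2 of the 4 values shown sit.

This single pair cannot separate the loss of the tert-butyl group from the gain of fluorine. Going by these compounds, how a plain phenyl, a methoxyphenyl or a pyridyl group would behave at this place remains open.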